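Replacing the 3,4-dihydroxyphenyl group of compound 3

The source may report more compounds than this note shows. Statements on the series, on what has been measured and on what is new or still open speak of the compounds shown alone.

Measured in a functional assay on MCF7 cells (Homo sapiens) for cytotoxicity, read by MTT assay, with a stated time of 48 h (a lower number here means a stronger inhibitor, a higher number a weaker inhibitor), so far
compound 1 `O=C1/C(=C\c2ccccc2)S/C(=N/c2ccccc2)N1Cc1ccncc1` gives 26400 nM
compound 2 `Cc1ccc(/C=C2/S/C(=N/c3ccccc3)N(Cc3ccncc3)C2=O)cc1` gives 36900 nM
compound 3 `O=C1/C(=C\c2ccc(O)c(O)c2)S/C(=N/c2ccccc2)N1Cc1ccncc1` gives 12400 nM

Compound 3 with 12400 nM stands lowest of the three, and its steps to both others lie beyond the scatter. Compound 4 `O=C1/C(=C\c2cccc(Cl)c2)S/C(=N/c2ccccc2)N1Cc1ccncc1` has 3-chlorophenyl in place of 3,4-dihydroxyphenyl on a double-bonded chain carbon bound to a double-bonded ring carbon, with 3-chlorophenyl in place of 3,4-dihydroxyphenyl on a double-bonded chain carbon bound to a double-bonded ring carbon as the count. Among the measured compounds shown here, two measured steps bear on this: a 2.1-fold lower number from compound 1 to compound 3 (0.33 log units; beyond the scatter) and a 3.0-fold lower number from compound 2 to compound 3 (0.47 log units; beyond the scatter) in turn, both modest and both bringing in 3,4-dihydroxyphenyl. The third shows a 1.4-fold higher number from compound 1 to compound 2 (0.15 log units; within the scatter) and no more. For the measured compounds named here, no chlorinated compound has been measured. Losing 3,4-dihydroxyphenyl should therefore bring a modest rise in this assay towards a higher number. A step of a 2.0-fold higher number from compound 3 to compound 4 (0.30 log units; within the scatter) is expected. Compound 4 is estimated at 25000 nM with an expected range of 11000 nM to 55000 nM for the measurement.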

Compound 4, half-maximal inhibitory concentration: 29800 nM
Compound 4: middle estimate off by 1.2-fold (0.08 log units), on the low side, and the stated range covers the measured number.
By their numbers in this assay, from the lowest: compound 3; then compounds 1, 4 and 2 (each within the scatter of the next).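

In this assay, 3-chlorophenyl does not keep the lower number seen with 3,4-dihydroxyphenyl, with a 2.4-fold higher number from compound 3 to compound 4 (0.38 log units; beyond the scatter) in this change. The chloro group alone adds nothing measurable, with a 1.1-fold higher number from compound 1 to compound 4 (0.05 log units; within the scatter) and with a 1.2-fold lower number from compound 2 to compound 4 (0.09 log units; within the scatter) for the exchange of 4-methylphenyl, so at this place only compound 3 stands apart from the other three. No evidence is available to explain this difference.

As far as these compounds go, whether a single hydroxyl, a methoxy group or an amine at this place would keep the number of compound 3 remains open. Changes elsewhere on the shared core also remain open.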